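The source may report more compounds than this note shows. Statements on the series, on what has been measured and on what is new or still open speak of the compounds shown alone.

Compound 1 `CC(=O)Nc1ccc(-c2cn([C@@H]3CN[C@H](C(=O)Nc4ccc(Cl)c(C(F)(F)F)c4)C3)nn2)cn1`: 33.6%
Compound 2 `O=C(Nc1ccc(-c2cn([C@@H]3CN[C@H](C(=O)Nc4ccc(Cl)c(C(F)(F)F)c4)C3)nn2)cn1)C1CC1`: 44.3%
Compound 3 `Nc1n[nH]c2cc(-c3cn([C@@H]4CN[C@H](C(=O)Nc5ccc(Cl)c(C(F)(F)F)c5)C4)nn3)ccc12`: 48.2%

In a functional assay on K562/Adr cells (Homo sapiens) for inhibition, read by MTT assay, with a stated time of 48 h, tested at 30 uM (a lower number here means less inhibition, a higher number more inhibition at the concentration tested (going by the name of the read-out)), compound 3 holds the highest of the three numbers: a number 3.9 percentage points higher from compound 2 to compound 3 (within the scatter), and a number 14.6 percentage points higher from compound 1 to compound 3 (beyond the scatter). Compound 4 `CC(=O)Nc1n[nH]c2cc(-c3cn([C@@H]4CN[C@H](C(=O)Nc5ccc(Cl)c(C(F)(F)F)c5)C4)nn3)ccc12` differs from compound 3 by acetyl in place of hydrogen on a nitrogen on an aromatic ring. For the measured compounds named here, no measured step adds an acetyl to a ring nitrogen. Going by the values given here, the closest case is a number 10.7 percentage points higher from compound 1 to compound 2 (beyond the scatter), which swaps one acyl group for another on a nitrogen, and compound 1, the one bearing an acetamido group, gives the lowest value of the three. Such a change is expected to move this assay little, if anywhere slightly lower, so for compound 4 the estimated step is a number 5.2 percentage points lower from compound 3 to compound 4 (within the scatter), giving an expected value of 43%, in a range from 28% to 58%.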

Compound 4, a percentage reported as inhibition, at one concentration (the size of the read-out at that concentration, not a potency): 23.4%
The estimate for compound 4 lay 19.6 percentage points above the measured number; measured number outside the range, below it.
By their numbers in this assay, from the lowest: compound 4; then compound 1; then compounds 2 and 3 (each within the scatter of the next).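

In this assay the change from amino to acetamido, on a nitrogen on an aromatic ring, gives a number 24.8 percentage points lower from compound 3 to compound 4 (beyond the scatter) and so marks this nitrogen as a place where adding an acetyl lowers the number. For the compounds shown here, the earlier compounds showed only one acyl group exchanged for another, never an acetyl set against hydrogen. No measurement at hand accounts for the fall. On these data alone, whether a cyclopropylcarbonyl group, a longer acyl chain such as butanoyl or a plain methyl on this nitrogen would lower the number as well remains open.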